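Swapping Methoxy for Trifluoromethyl on a Benzyl Amide

The source may report more compounds than this note shows. Statements on the series, on what has been measured and on what is new or still open speak of the compounds shown alone.

Compound 2, `CCN(C(=O)C1CCN(S(=O)(=O)c2ccc3cn[nH]c3c2)CC1)[C@H](C)c1ccccc1`, gives 87% in a functional assay on CHO cells for positive allosteric modulation of muscarinic acetylcholine receptor M5 (Homo sapiens), read by calcium flux; a lower number here means a smaller maximal response, a higher number a larger maximal response.
Compound 3, `CCN(Cc1cccc(OC)c1)C(=O)C1CCN(S(=O)(=O)c2ccc3cn[nH]c3c2)CC1`, gives 85% in this assay.
Compound 1, `CCN(Cc1ccccc1)C(=O)C1CCN(S(=O)(=O)c2cccc3nsnc23)CC1`, is reported in this assay as "not determined" (no result reported).

Compound 3 holds the lower of the two numbers available, but its nearest neighbour, compound 2, sits within the usual scatter of it, so the two cannot be told apart; compound 1 adds no number. Going by the values given here, the one measured step, a number 2 percentage points lower from compound 2 to compound 3 (within the scatter), exchanges a 1-phenylethyl group for a 3-methoxybenzyl group on the amide-type nitrogen and leaves the maximal response essentially unchanged.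

Compound 4, `CCN(Cc1cccc(C(F)(F)F)c1)C(=O)C1CCN(S(=O)(=O)c2ccc3cn[nH]c3c2)CC1`, is not yet measured. It differs from compound 3 in one place: trifluoromethyl in place of methoxy on an aromatic carbon. Among the compounds with values here, this is a smaller change than the one from compound 2 to compound 3, again on the benzyl part of the shared core, and that change stayed within the scatter. Within the data shown here, no measured step tells how this particular exchange acts on the maximal response.

Given that the only known step, a number 2 percentage points lower from compound 2 to compound 3 (within the scatter), lay within the scatter, the step of no change at the digits printed from compound 3 to compound 4 (within the scatter) is expected to be small as well. Compound 4 is therefore estimated at 85%, with a range from 70% to 98%.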

Compound 4, largest response reached (reported as percent of maximum), in percent of the reference or control that the assay uses: 59%
Estimate against measurement, compound 4: 26 percentage points above, and the stated range ends above it.
By their numbers in this assay, from the lowest: compound 4; then compounds 3 and 2 (each within the scatter of the next).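

Going by these compounds alone, on the benzyl part of the shared core, the group on this aromatic carbon matters in this assay: the exchange of methoxy for trifluoromethyl gives a number 26 percentage points lower from compound 3 to compound 4 (beyond the scatter) and is the first step beyond the scatter in this small set, although only one group changes. The broader exchange on the amide-type nitrogen gives a number 28 percentage points lower from compound 2 to compound 4 (beyond the scatter) and so differs from the earlier swap of 1-phenylethyl for 3-methoxybenzyl, which stayed within the scatter, showing that this part of the molecule does not tolerate every change equally. Nothing at hand explains why the maximal response is lower with trifluoromethyl at this place.

Going by these compounds, with only methoxy and trifluoromethyl compared here, it remains open whether a group such as a fluorine, a nitrile or an amine on the same aromatic carbon would give a response closer to that of compound 3 or that of compound 4. On these data alone, it is also open whether trifluoromethyl would lower the response to a similar extent in a compound with a different group on the amide-type nitrogen.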